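Chloro on the fused ring of a sugar-bearing core

This account rests on a few compounds, and the source may have more. Where it says the series, first, only, none or still open, it means among the compounds named here.

Of the compounds shown here, three have been tested in a functional assay on HepG2 cells (Homo sapiens) for cytotoxicity, read by MTT assay, with a stated time of 24 h; a higher number here means a weaker inhibitor, a lower number a stronger inhibitor. Compound 1 `CC1(C)OC2O[C@@H](Cc3cn4ccccc4nc3=O)C(OCc3ccccc3)C2O1` gives > 1000000 nM, which is a limit of the assay rather than a number. Compound 3 `O=c1nc2ccc(Br)cn2cc1Cc1ccccc1` gives > 1000000 nM, again a limit. Compound 2 `O=c1nc2ccc(Br)cn2cc1Cc1ccc(Cl)cc1` gives > 1000000 nM, also a limit. The change from compound 3 to compound 2 is chloro in place of hydrogen on an aromatic carbon, and the step it made is a step that the two limits leave unreadable from compound 3 to compound 2, because of the limit of > 1000000 nM in this assay, at which 3 of the 3 values shown sit. How the core of compound 1 differs from that of compound 3 is not broken down here. Compound 4 `CC1(C)OC2O[C@@H](Cc3cn4cc(Cl)ccc4nc3=O)C(OCc3ccccc3)C2O1` carries the same kind of change as compound 2, (chloro in place of hydrogen on an aromatic carbon), though here the place is a six-membered aromatic ring with one nitrogen, part of a fused system, rather than a ring of carbon only. The step from compound 1 to compound 4 is expected to be a step that the limit leaves unreadable from compound 1 to compound 4, resting on the limit of compound 1, > 1000000 nM. Compound 4 is therefore expected to give 2000000 nM, most likely as a further limit.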

Compound 4, half-maximal inhibitory concentration: > 1000000 nM
Compound 4 gave a limit, no number; the forecaster's own chance of this, stated with the estimate: 90%; the middle value does not contradict the limit.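

Compound 1 and compound 4 both sit at a limit rather than a number, so no step can be read between them, because of this: the limit of > 1000000 nM in this assay, at which 4 of the 4 values shown sit.

What chloro in place of hydrogen does to cytotoxicity on either core stays open: no compound shown gives a number.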